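One Added Methyl and What It May Cost

The compounds below may be only part of what the source reports. "The series", "measured", "known", "first", "only" and "open" are said of these compounds alone.

Compound 1 `CC(=O)N(C)C(C)C#CCn1cncc1C`: in a functional assay on the whole organism for agonist activity, with Mus musculus as the target (a higher number here means that more compound is needed for the effect, a lower number that less compound is needed), compound 1 reached only the assay limit, > 100 mg/kg.
Compound 2 `CC(=O)N(C)CC#CCn1cncc1C`: in this assay compound 2 gave 5.4 mg/kg.
Compound 3 `COC(=O)N(C)CC#CCN1CCCC1`: in this assay compound 3 gave 1.4 mg/kg.

Going by the values given here, of the two numbers known, compound 3 has the lower one, and compound 2 stands higher. The cores of compound 2 and compound 3 differ in more than one place; that difference is not broken down here. Compound 4 `COC(=O)N(C)C(C)C#CCN1CCCC1` has not yet been measured. It differs from compound 3 by methyl in place of hydrogen on a saturated chain carbon bound to an amide-type nitrogen and a triple-bonded carbon. The same change, (methyl in place of hydrogen on a saturated chain carbon bound to an amide-type nitrogen and a triple-bonded carbon), gave an at least 18-fold higher number from compound 2 to compound 1 (1.26 log units; beyond the scatter), a large step into the limit region. Compound 4 is therefore expected to show a similarly large step, a 29-fold higher number from compound 3 to compound 4 (1.46 log units; beyond the scatter), because the same change gave an at least 18-fold higher number from compound 2 to compound 1 (1.26 log units; beyond the scatter). Compound 4 is estimated at about 40 mg/kg, with a likely range from 12 mg/kg to 150 mg/kg, and it may itself end at the assay limit.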

Compound 4, dose for half-maximal effect: 9.7 mg/kg
The estimate for compound 4 lay 4.1-fold (0.62 log units) above the measured number; measured number outside the range, below it.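

With the methyl on a second core, this assay showed a 6.9-fold higher number from compound 3 to compound 4 (0.84 log units; beyond the scatter), the same direction as on the first core. This suggests that the direction of the change carries over between these two cores, though not that its size does: the same change on two cores in this assay, an at least 18-fold higher number (1.26 log units; beyond the scatter) from compound 2 to compound 1 and a 6.9-fold higher number (0.84 log units; beyond the scatter) from compound 3 to compound 4; the limit leaves it open whether they differ. Two cores are also too few to make this a rule for the whole series.

The compounds shown leave open whether a larger group on the same carbon, such as ethyl or hydroxymethyl, would raise the number further or less. They also leave open what the methyl would do on a core carrying an open-chain amine such as diethylamino in place of the groups seen here.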